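The compounds below may be only part of what the source reports. "The series", "measured", "known", "first", "only" and "open" are said of these compounds alone.

Compound 2 `CNCc1ccccc1Oc1ccc(Cl)cc1F` shares its core with compound 1 `CNCc1ccccc1Oc1ccc(OC)cc1Cl` and compound 3 `CNCc1cc(C#N)ccc1Oc1ccc(Cl)cc1Cl`, which were both examined in an assay on HEK293 cells for inhibition of sodium-dependent dopamine transporter (Homo sapiens); on this read-out higher numbers stand for weaker inhibition and lower numbers for stronger inhibition. Compound 1 gives 5950 nM in this assay, and compound 3 gives 3010 nM; the two numbers lie close together. For compound 2 this assay reports "not determined" (no result reported), so its position rests only on what compounds 1 and 3 show. Compound 4 `CN(C)Cc1ccccc1Oc1ccc(Cl)cc1F` arises from compound 2 through one change: methyl in place of hydrogen on an amine nitrogen. With no measured step of this kind in the set, only a modest shift is expected, if any, probably toward weaker inhibition and possibly not beyond the scatter. For compound 4 in this assay a value near 7000 nM is estimated, expected to fall between 1800 nM and 28000 nM.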

Compound 4, half-maximal inhibitory concentration: 421 nM
The estimate for compound 4 lay 17-fold (1.22 log units) above the measured number, and the stated range ends above it.
By their numbers in this assay, from the lowest: compound 4; then compounds 3 and 1 (each within the scatter of the next).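

No step can be read for compound 2 and compound 4, as compound 2 has no number in this assay to set against compound 4 at 421 nM. The compounds shown leave open how much methyl in place of hydrogen on the amine nitrogen shifts this value. No evidence shown bears on the result.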